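Oxime ether variants: estimating the benzyloxy analogue

The compounds below may be only part of what the source reports. "The series", "measured", "known", "first", "only" and "open" are said of these compounds alone.

Measured compounds, a physicochemical assay for lipophilicity, using the shake flask method; on this read-out lower numbers stand for lower lipophilicity and higher numbers for higher lipophilicity:
Compound 1, `CCO/N=C/c1c(N)ncnc1Oc1ccc(NC(=O)C2(C(=O)Nc3ccc(F)cc3)CC2)cc1F`, gives 3.41.
Compound 2, `CC(C)(C)OC(=O)N/N=C/c1c(N)ncnc1Oc1ccc(NC(=O)C2(C(=O)Nc3ccc(F)cc3)CC2)cc1F`, gives 3.7.
Compound 3, `CCOC(=O)CO/N=C/c1c(N)ncnc1Oc1ccc(NC(=O)C2(C(=O)Nc3ccc(F)cc3)CC2)cc1F`, gives 3.15.

Compound 1 stands second highest of the three numbers in this assay; its nearest neighbour is compound 3 with a number 0.26 log units lower from compound 1 to compound 3 (within the scatter), the furthest compound 2 with a number 0.29 log units higher from compound 1 to compound 2 (within the scatter). Compound 4, `Nc1ncnc(Oc2ccc(NC(=O)C3(C(=O)Nc4ccc(F)cc4)CC3)cc2F)c1/C=N/OCc1ccccc1`, differs from compound 1 by phenyl in place of methyl on a saturated chain carbon bound to an oxygen on an unsaturated carbon. The step of a number 0.26 log units lower from compound 1 to compound 3 (within the scatter) concerns the same place but a different entering group; the steps of a number 0.29 log units higher from compound 1 to compound 2 (within the scatter) and a number 0.55 log units lower from compound 2 to compound 3 (beyond the scatter) change the group on the double-bonded nitrogen. Within the data shown here, no measured step adds a phenyl ring, so the measured series gives only the baseline of compound 1. The expectation for compound 4 is an upward step, a number 0.99 log units higher from compound 1 to compound 4 (beyond the scatter), beyond the scatter. Compound 4 is estimated at 4.4, within 3.9 to 5.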

Compound 4, partition coefficient: 4.45
For compound 4 the middle estimate is 0.05 log units below the measured one, within the range that was stated.
By their numbers in this assay, from the lowest: compounds 3, 1 and 2 (each within the scatter of the next, the first and the last beyond it); then compound 4.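

In this assay, among these compounds, the change from ethoxy to benzyloxy gives the first step at this position that lies beyond the scatter (a number 1.04 log units higher from compound 1 to compound 4 (beyond the scatter)). Phenyl in place of ethoxycarbonyl at the same place gives a still larger step (a number 1.30 log units higher from compound 3 to compound 4 (beyond the scatter)), and benzyloxy in place of (tert-butoxycarbonyl)amino on the double-bonded nitrogen gives a modest one (a number 0.75 log units higher from compound 2 to compound 4 (beyond the scatter)). Nothing available explains the size of these steps.

Open, from the compounds shown here alone, is whether a pyridyl ring, a longer chain or an amine on this saturated chain carbon would give a step of similar size. Also open, going by these compounds, is whether substituents on the phenyl ring would move the number further.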